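A few compounds are considered here, and "the series" means these few. Any claim that something is new, unique, unknown or untested is made for them only; others in the source may bear on it.

Measured so far in an ADME assay on Vero cells (Chlorocebus sabaeus) for cytotoxicity, with a stated time of 72 h; on this read-out lower numbers stand for stronger inhibition and higher numbers for weaker inhibition:
Compound 1 `CCOC(=O)c1cc(/C=C/c2ccccc2C(F)(F)F)on1`: "not determined" (no result reported)
Compound 2 `CCOC(=O)c1cc(/C=C/c2cccc(C(C)C)c2)on1`: > 128000 nM

Compound 1 has no result, so it offers no comparison. Compound 2 reads > 128000 nM, which is a limit of the assay and not a number. This gives only the position shown in the limit of > 128000 nM in this assay, at which 1 of the 2 values shown sits, and no exact standing can be stated.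

Compound 3 `CCOC(=O)c1cc(/C=C/c2cccc([N+](=O)[O-])c2)on1` has nitro in place of isopropyl on an aromatic carbon, meta to a large group. Going by the values given here, no measured step shows what such a change does in this assay, so any expectation is cautious. A small step towards lower numbers is expected, or none that can be seen, and compound 3 may well report only a limit too. The estimated change is an at least 1.2-fold lower number from compound 2 to compound 3 (0.10 log units; that floor lies within the scatter). For compound 3 the expected value is 100000 nM, with an estimated range of 35000 nM to 128000 nM.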

Compound 3, half-maximal inhibitory concentration: > 128000 nM
Compound 3: a limit, no number; the forecaster's own chance of this, stated with the estimate: 60%; middle value at least 1.2-fold (0.10 log units) away from the limit.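

In this assay, compound 2 and compound 3 each report only a limit and not a number, so no step can be read between them: the limit of > 128000 nM in this assay, at which 2 of the 3 values shown sit.

The compounds shown leave open whether nitro in place of isopropyl on an aromatic carbon changes the value at all.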